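The source may hold more compounds than are shown below. What is called first, only, known or untested is meant among the compounds shown, and "the series" means these compounds.

Compound 3 `COc1cc(OC)cc(-c2ccc(-c3ccc(C(=N)N)c(F)c3)s2)c1` sits at the lower of the two numbers recorded in a functional assay on RXF 393 cells (Homo sapiens) for inhibition, read by sulforhodamine B assay, with a stated time of 48 h; on this read-out lower numbers stand for stronger inhibition of growth and higher numbers for weaker inhibition of growth. In this assay compound 3 gives 449 nM. Its nearest neighbour on that read-out, compound 2 `N=C(N)c1ccc(-c2ccc(-c3ccc(F)cc3)s2)cc1`, gives 1480 nM in this assay, a higher number that lies beyond the scatter. Compound 1 `N=C(N)c1ccc(-c2ccc(-c3cc(Cl)cc(Cl)c3)s2)cc1` is also part of the series, but for compound 1 this assay returned "not determined" (no result reported), so compound 3 can be set against compound 2 alone.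

Compound 4 `COc1cc(OC)cc(-c2ccc(-c3ccc(C(=N)N)cc3)s2)c1` has not yet been measured in this assay. It is built from compound 3 by a single change: hydrogen in place of fluoro on an aromatic carbon. Going by the values given here, no step between two measured compounds mirrors that change, so there is no measured guide to its effect. Without such a precedent, the account expects a step from compound 3 to compound 4 of modest size, most likely within the usual scatter, with no firm direction. On that basis compound 4 is estimated at 600 nM in this assay, expected to fall between 250 nM and 1400 nM, a shift of a 1.3-fold higher number from compound 3 to compound 4 (0.13 log units; within the scatter).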

Compound 4, concentration for 50% growth inhibition: 1810 nM
Estimate against measurement, compound 4: 3.0-fold (0.48 log units) below; measured number outside the range, above it.
By their numbers in this assay, from the lowest: compound 3; then compounds 2 and 4 (each within the scatter of the next).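

In this assay, putting hydrogen in place of fluoro on this aromatic carbon gives a 4.0-fold higher number from compound 3 to compound 4 (0.61 log units; beyond the scatter) and so reaches beyond the scatter. Going by these compounds alone, until this pair, no measured step had isolated a single place, so this is the first sign that the position, ortho to a group of 3 heavy atoms and meta to a large group, matters for growth inhibition, although it rests on one pair alone. Nothing measured here offers a reason for this step.

The compounds shown leave open whether another group at this carbon, such as chloro, methoxy or an amine, would match or improve on the fluoro. They also leave open whether the same exchange would produce a step of similar size on the core of compound 2.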